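Swapping methyl for methoxy on the aryl ether of compound 2

The source may hold more compounds than are shown below. What is called first, only, known or untested is meant among the compounds shown, and "the series" means these compounds.

Measured so far:
Compound 1, `Cc1cccc(Oc2ccc(N3CCC[C@H]3CC(=O)O)cc2)c1`: 260 nM
Compound 2, `Cc1ccc(Oc2ccc(N3CCC[C@H]3CC(=O)O)cc2)cc1`: 490 nM

Both compounds were tested in a functional assay on cells for agonist activity at Free fatty acid receptor 1 (Homo sapiens), read by FLIPR and calcium flux, with a stated time of 100 s; on this read-out lower numbers stand for an effect already at smaller amounts and higher numbers for an effect only at larger amounts of compound. Within the data shown here, compound 2 gives 490 nM and compound 1 gives 260 nM; the only change between them is 4-methylphenyl in place of 3-methylphenyl on an oxygen on an aromatic ring, and that step, a 1.9-fold higher number from compound 1 to compound 2 (0.28 log units; within the scatter), stays within the scatter of the method. So the two numbers count as alike.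

Compound 3, `COc1ccc(Oc2ccc(N3CCC[C@H]3CC(=O)O)cc2)cc1`, is not yet measured. It differs from compound 2 by methoxy in place of methyl on an aromatic carbon, described as methoxy in place of methyl on an aromatic carbon, para to a large group. Among the measured compounds shown here, no measured step changes this group, so nothing here shows how such a swap moves the read-out. The expected step, therefore, is a 1.0-fold higher number from compound 2 to compound 3 (0.01 log units; within the scatter), with wide uncertainty. For compound 3 the estimate in this assay is 500 nM, ranging from 180 nM to 1500 nM.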

Compound 3, half-maximal effective concentration: 520 nM
Compound 3: middle estimate off by 1.0-fold (0.02 log units), on the low side, within the range that was stated.
By their numbers in this assay, from the lowest: compounds 1, 2 and 3 (each within the scatter of the next).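

In this assay methoxy in place of methyl on the aromatic carbon para to a large group gives a 1.1-fold higher number from compound 2 to compound 3 (0.03 log units; within the scatter) and so leaves the read-out unchanged within the scatter, even though the swap brings in an oxygen and a hydrogen-bond acceptor. The step that replaces 3-methylphenyl with 4-methoxyphenyl gives a 2.0-fold higher number from compound 1 to compound 3 (0.30 log units; within the scatter) and also stays within the scatter, so compounds 1, 2 and 3 all count as alike in this read-out. Nothing available explains why these changes leave the numbers so close.

Still open, going by these compounds, is whether a group of a different kind at this position, such as an amine or a longer chain like butoxy, would move the read-out beyond the scatter. These three compounds show only that methyl and methoxy are alike here, and they say nothing about other groups.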